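The source may hold more compounds than are shown below. What is called first, only, known or untested is meant among the compounds shown, and "the series" means these compounds.

Working notes on the series. Compound 1 `CCCCCCCCCCCCCCCCCCNC(=O)[C@@H]1CSC(c2cccc(O)c2)N1` and compound 2 `CCCCCCCCCCCCCCCCCCNC(=O)[C@@H]1CSC(c2ccc(O)cc2)N1` share one core and differ only in the position of the hydroxy group on the phenyl ring. In a functional assay on PPC-1 cells (Homo sapiens) for antiproliferative activity, read by sulforhodamine B assay (on this read-out lower numbers stand for stronger inhibition and higher numbers for weaker inhibition), compound 1 gives 1200 nM, and in the same assay compound 2 gives 820 nM. Going by the values given here, the step of a 1.5-fold lower number from compound 1 to compound 2 (0.17 log units; within the scatter) is the only measured step so far; the two numbers sit within the scatter of each other, so no ranking between compound 1 and compound 2 is warranted.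

Compound 3 `CCCCCCCCCCCCCCCCCCNC(=O)[C@@H]1CSC(c2ccc(OCC)cc2)N1` is the next member and has not yet been measured. It differs from compound 2 by ethyl in place of hydrogen on an oxygen on an aromatic ring. Among the compounds with values here, no measured step bears on this change: the one step on record moves the hydroxy group around the ring and does not touch the hydrogen on its oxygen. With nothing to anchor the direction, the expectation for compound 3 in this assay is a step no larger than the scatter, a 1.2-fold higher number from compound 2 to compound 3 (0.09 log units; within the scatter), and the estimate for compound 3 is 1000 nM with a range of 300 nM to 3500 nM.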

Compound 3, half-maximal inhibitory concentration: 4400 nM
The estimate for compound 3 lay 4.4-fold (0.64 log units) below the measured number, and the stated range ends below it.
By their numbers in this assay, from the lowest: compounds 2 and 1 (each within the scatter of the next); then compound 3.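

In this assay, going by these compounds alone, the oxygen on the aromatic ring is the first place where a change gives a step beyond the scatter: ethyl in place of hydrogen there gives a modest rise (a 5.4-fold higher number from compound 2 to compound 3 (0.73 log units; beyond the scatter)), whereas moving the hydroxy group around the ring left compound 1 and compound 2 within the scatter of each other. The wider change from 3-hydroxyphenyl to 4-ethoxyphenyl also gives a step beyond the scatter (a 3.7-fold higher number from compound 1 to compound 3 (0.56 log units; beyond the scatter)), so among these three compounds, both hydroxy compounds have lower numbers than the ethoxy compound. Nothing available explains this step.

The compounds shown leave open whether the higher number goes with the loss of the hydrogen on that oxygen or with the ethyl that replaces it, since only one group has been shown there. A methyl or a longer chain on the same oxygen, or an amine in place of the hydroxy group, would show whether the step depends on the size of the group or on the hydroxy group itself.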